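From compound 3 to compound 4: a ring swap

This account rests on a few compounds, and the source may have more. Where it says the series, first, only, none or still open, it means among the compounds named here.

Results so far in an ADME assay on microsomes from liver (Mus musculus) for metabolic stability, read by LC-MS, with a stated time of 10 min; on this read-out higher numbers stand for a more stable compound and lower numbers for a less stable compound
- compound 1 `CN(C[C@H]1Cc2c(cccc2N2CCN(C3COC3)CC2)CN1)[C@H]1CCCc2cccnc21` gives 50.8%
- compound 2 `CN(C[C@H]1Cc2c(cccc2N2CCNC(C)(C)C2)CN1)[C@H]1CCCc2cccnc21` gives 44%
- compound 3 `CN1CCN(c2cccc3c2C[C@H](CN(C)[C@H]2CCCc4cccnc42)NC3)CC1` gives 17%

Compound 3 stands lowest of the three. Compound 4 `CN(C[C@H]1Cc2c(cccc2N2C[C@H]3C[C@@H]2CN3)CN1)[C@H]1CCCc2cccnc21` differs from it in one place: a group of 7 heavy atoms (5 carbon, 2 nitrogen; 2 five-membered non-aromatic rings with 1 hetero atom each) in place of a group of 7 heavy atoms (5 carbon, 2 nitrogen; one six-membered non-aromatic ring with 2 hetero atoms), on an aromatic carbon. Going by the values given here, two measured steps bear on this change, a number 33.8 percentage points lower from compound 1 to compound 3 (beyond the scatter) and a number 27 percentage points lower from compound 2 to compound 3 (beyond the scatter). Among the compounds with values here, both end at the only compound with a methyl on that ring nitrogen, and compound 4 has no such methyl. No group with these two five-membered rings has been measured, so any guess is loose. A moderate rise is expected in this assay, with an estimated step of a number 18 percentage points higher from compound 3 to compound 4 (beyond the scatter). The expected value for compound 4 is 35%, with an estimated range of 15% to 60%.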

Compound 4, percent of the compound remaining: 95.9%
Compound 4: middle estimate off by 60.9 percentage points, on the low side; measured number above the stated range.
By their numbers in this assay, from the lowest: compound 3; then compounds 2 and 1 (each within the scatter of the next); then compound 4.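

In this assay the new group on the aromatic carbon gives a number 78.9 percentage points higher from compound 3 to compound 4 (beyond the scatter) and likewise a number 51.9 percentage points higher from compound 2 to compound 4 (beyond the scatter) and a number 45.1 percentage points higher from compound 1 to compound 4 (beyond the scatter), so it stands clear of all three piperazine groups. Compounds 3 and 4 carry groups with the same count of carbon and nitrogen atoms, so the arrangement of the rings at this position can matter greatly, not only what sits on a ring nitrogen. Nothing measured here explains the rise. Still open, on these data alone, is whether a methyl or an oxetan-3-yl on the free ring nitrogen of the new group would keep this number. A morpholin-4-yl group at the same carbon is also untested in what is shown here.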